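This account rests on a few compounds, and the source may have more. Where it says the series, first, only, none or still open, it means among the compounds named here.

Measured so far in a functional assay on NCI-H661 cells (Homo sapiens) for antiproliferative activity, read by MTT assay, with a stated time of 72 h; a lower number here means a stronger inhibitor of growth, a higher number a weaker inhibitor of growth:
- Compound 1 `O=C(COc1ccc2c(=O)cc(-c3ccccc3)oc2c1)Nc1ccc2ccccc2c1`: compound 1 gives > 10000 nM, a limit of the assay, not a number.
- Compound 2 `O=C(COc1ccc2oc(-c3ccccc3)cc(=O)c2c1)Nc1ccc(-c2ccccc2)cc1`: compound 2 gives 9710 nM.
- Compound 3 `O=C(COc1ccc2c(=O)cc(-c3ccccc3)oc2c1)Nc1ccc(F)cc1`: compound 3 gives 5770 nM.

Going by the values given here, compound 3 holds the lowest number of the two numbers so far; its nearest neighbour is compound 2, whose number is higher only within the scatter. Among the compounds with values here, the one measured step, an at least 1.7-fold lower number from compound 1 to compound 3 (0.23 log units; that floor lies within the scatter), is bounded by the limit described in the limit of > 10000 nM in this assay, at which 1 of the 3 values shown sits, and does not reach beyond the scatter.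

Compound 4 `O=C(COc1ccc2c(=O)cc(-c3ccccc3)oc2c1)Nc1ccc(-c2ccccc2)cc1` differs from compound 3 by phenyl in place of fluoro on an aromatic carbon. Within the data shown here, no measured step follows this same change on the shared core, so the size of the step cannot be read from a measured pair. Compound 2 carries the same biphenyl amide on a different arrangement of the core and gives a number close to compound 3, within the scatter. The step of a 1.5-fold higher number from compound 3 to compound 4 (0.17 log units; within the scatter) is therefore expected to be small and, if anything, towards a higher number. Compound 4 is estimated at 8500 nM in this assay, with a range from 3000 nM to 25000 nM.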

Compound 4, concentration for 50% growth inhibition: 1280 nM
The estimate for compound 4 lay 6.6-fold (0.82 log units) above the measured number; the whole stated range lies above it.
By their numbers in this assay, from the lowest: compound 4; then compounds 3 and 2 (each within the scatter of the next). At a limit, above all of these: compound 1.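

In this assay, going by these compounds alone, phenyl in place of fluoro on an aromatic carbon, para to a large group, gives a 4.5-fold lower number from compound 3 to compound 4 (0.65 log units; beyond the scatter), the first step to lie beyond the scatter. This position on the shared core therefore takes a second aromatic ring, six heavy atoms in place of one, and the number falls rather than rises. The biphenyl amide does not give this result on every core arrangement: compound 2, with the same amide on a different arrangement of the core, gives 9710 nM, while compound 4 gives 1280 nM.

Nothing shown gives a reason for this step. Whether the lower number depends on an aromatic ring at this carbon remains open, as the compounds shown include no morpholine, carboxylic acid or longer alkyl chain there.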